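Fluoro to nitro swap: cytotoxicity notes on the series

This account rests on a few compounds, and the source may have more. Where it says the series, first, only, none or still open, it means among the compounds named here.

Measured so far:
- compound 1, `O=C(CSc1nccn1-c1ccc(Cl)cc1)Nc1ccccc1F`: > 345000 nM
- compound 2, `O=C(CSc1nccn1-c1ccc(Cl)cc1)Nc1ccccc1[N+](=O)[O-]`: > 321000 nM
- compound 3, `O=C(CSc1nccn1-c1cccc2ccccc12)Nc1ccccc1F`: 34700 nM

In an ADME assay on MT4 cells (Homo sapiens) for cytotoxicity, read by MTT assay (on this read-out higher numbers stand for lower toxicity in this test and lower numbers for higher toxicity in this test), compound 1 gives > 345000 nM, which is a limit of the assay and not a number. Compound 2 gives > 321000 nM, also a limit. The change between them is nitro in place of fluoro on an aromatic carbon. The size of a step that the two limits leave unreadable from compound 1 to compound 2 is therefore not readable, due to the limit of > 345000 nM in this assay, at which 1 of the 3 values shown sits, holding compound 1. Compound 2 likewise sits at the limit of > 321000 nM in this assay, at which 1 of the 3 values shown sits. Among the measured compounds shown here, compound 3 gives 34700 nM, the only actual number among the three; the difference between its core and the core of compound 1 is not broken down here.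

Compound 4, `O=C(CSc1nccn1-c1cccc2ccccc12)Nc1ccccc1[N+](=O)[O-]`, is compound 3 with nitro in place of fluoro on an aromatic carbon. The place of this change reads word for word the same as in the pair compound 1 to compound 2, so it is the same change, seen twice in the set, but its measured instance gives no readable size. For the measured compounds named here, with no usable precedent, compound 4 is expected to stay close to compound 3, so the expected step is a 1.0-fold higher number from compound 3 to compound 4 (0.00 log units; within the scatter). Compound 4 is estimated at 35000 nM, between 12000 nM and 110000 nM.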

Compound 4, half-maximal cytotoxic concentration: 28800 nM
Beside the measured number, compound 4's estimate is 1.2-fold (0.08 log units) above it; the range from low to high includes it.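

In this assay, nitro in place of fluoro on an aromatic carbon gives a 1.2-fold lower number from compound 3 to compound 4 (0.08 log units; within the scatter), which is one readable instance on the core of compound 3 and does not show whether the change carries to the core of compound 1. The same change on the core of compound 1 cannot be read, as compound 1 is a limit of the assay and not a number: the limit of > 345000 nM in this assay, at which 1 of the 4 values shown sits.

Compound 2 is also a limit of the assay and not a number, so the change has a readable size on only one core and no transfer between cores is shown: the limit of > 321000 nM in this assay, at which 1 of the 4 values shown sits.

Still open, from the compounds shown here alone, is whether other groups in the same place, such as an amine, a carboxylic acid or a longer chain, would read like fluoro and nitro on the core of compound 3. Also open, going by these compounds, is how 2-fluorophenyl to 2-nitrophenyl would read on a further core where both partners give a number.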